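Changing the Ring on the Sulfonamide Nitrogen

The source may report more compounds than this note shows. Statements on the series, on what has been measured and on what is new or still open speak of the compounds shown alone.

In a functional assay on SF-268 cells (Homo sapiens) for antiproliferative activity, read by sulforhodamine B assay, with a stated time of 72 h (a higher number here means a weaker inhibitor, a lower number a stronger inhibitor), compound 1 (`Cc1cc(C)nc(NS(=O)(=O)c2ccc(Nc3nncc4ccccc34)cc2)n1`) gives 7.6 nM as the lowest number of the three, while compound 2 (`O=S(=O)(Nc1ncccn1)c1ccc(Nc2nncc3ccccc23)cc1`) gives 34 nM and compound 3 (`O=S(=O)(Nc1ccccn1)c1ccc(Nc2nncc3ccccc23)cc1`) gives 25 nM with no real separation from compound 2. Compound 3 therefore stands level with compound 2, and both read higher than compound 1.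

The unmeasured compound 4 (`Cc1cc(NS(=O)(=O)c2ccc(Nc3nncc4ccccc34)cc2)no1`) carries 5-methyl-1,2-oxazol-3-yl in place of pyridin-2-yl on a sulfonamide nitrogen. Going by the values given here, three measured steps touch this same place. Two were modest (a 4.5-fold higher number from compound 1 to compound 2 (0.65 log units; beyond the scatter)) and (a 3.3-fold higher number from compound 1 to compound 3 (0.52 log units; beyond the scatter)), and one stayed within the scatter (a 1.4-fold lower number from compound 2 to compound 3 (0.13 log units; within the scatter)). None of them tests the new ring directly, so no large step is expected. A slight move toward a lower number is expected, since compound 4 bears a methyl group as does compound 1 (7.6 nM). The expected step is small (a 1.3-fold lower number from compound 3 to compound 4 (0.10 log units; within the scatter)) and is not expected to clear the scatter. In this assay the estimated value for compound 4 is 20 nM (8 nM to 50 nM).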

Compound 4, half-maximal inhibitory concentration: 24 nM
Compound 4: the middle estimate sits 1.2-fold (0.08 log units) below what was measured; the range from low to high includes it.
By their numbers in this assay, from the lowest: compound 1; then compounds 4, 3 and 2 (each within the scatter of the next).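

In this assay, a five-membered ring on the sulfonamide nitrogen reads the same as the six-membered rings: 5-methyl-1,2-oxazol-3-yl cannot be separated from pyridin-2-yl (a 1.0-fold lower number from compound 3 to compound 4 (0.02 log units; within the scatter)) or from pyrimidin-2-yl (a 1.4-fold lower number from compound 2 to compound 4 (0.15 log units; within the scatter)). Its methyl group does not bring the number to the level of compound 1 (a 3.2-fold higher number from compound 1 to compound 4 (0.50 log units; beyond the scatter)), so among these four compounds only the 4,6-dimethylpyrimidin-2-yl group stands apart, and carrying a methyl group does not by itself go with that lower number. Nothing measured here offers an explanation for why these rings read alike.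

The compounds shown leave open how 1,2-oxazol-3-yl without its methyl group or 4-methylpyrimidin-2-yl would read, which would separate the methyl groups from the rings that carry them. They also leave open whether a saturated ring such as piperidine or an open chain such as acetyl on the sulfonamide nitrogen would read like the aromatic rings.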